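Swapping a Methylphenyl for a Methylbenzoyl Group

The source may report more compounds than this note shows. Statements on the series, on what has been measured and on what is new or still open speak of the compounds shown alone.

Compound 1 `Cc1ccccc1NNC(=O)c1ccc(NS(=O)(=O)c2cnc(O)nc2O)cc1`: > 20000 nM
Compound 2 `Cc1cccc(NNC(=O)c2ccccc2NS(=O)(=O)c2cnc(O)nc2O)c1`: > 20000 nM
Compound 3 `O=C(NNC(=O)c1cccc(NS(=O)(=O)c2cnc(O)nc2O)c1)c1ccc(F)cc1`: > 20000 nM

In a functional assay on MDA-MB-231 cells (Homo sapiens) for antiproliferative activity, read by MTT assay, with a stated time of 24 h (on this read-out lower numbers stand for stronger inhibition and higher numbers for weaker inhibition), compound 2 gives > 20000 nM, which is a limit of the assay and not a number. The set offers nothing firmer than the limit of > 20000 nM in this assay, at which 3 of the 3 values shown sit. So compound 2 has no measured potency to start from, and no step between measured compounds is available as a guide.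

Compound 4 `Cc1ccccc1C(=O)NNC(=O)c1ccccc1NS(=O)(=O)c1cnc(O)nc1O` is still unmeasured. It carries (2-methylphenyl)carbonyl in place of 3-methylphenyl on an amine nitrogen. Compound 3 also has a carbonyl-bearing group on the corresponding nitrogen, and it gives > 20000 nM, again only a limit. On that basis, no change beyond the usual scatter is expected in this assay, and the assay will probably report a limit again. The expected size of the move is a step that the limit leaves unreadable from compound 2 to compound 4. For compound 4 the estimated value is 28000 nM, with an expected range from 10000 nM to 60000 nM.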

Compound 4, half-maximal inhibitory concentration: 5570 nM
Compound 4: middle estimate off by 5.0-fold (0.70 log units), on the high side; the whole stated range lies above it.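

Replacing 3-methylphenyl with (2-methylphenyl)carbonyl on an amine nitrogen gives an at least 3.5-fold lower number from compound 2 to compound 4 (0.55 log units; beyond the scatter) in this assay. Within the data shown here, this shows that a change at this nitrogen can give the series a measurable value, and compound 4 gives the first firm number here, 5570 nM. The true size of the step remains unknown because compound 2 sits at a limit: the limit of > 20000 nM in this assay, at which 3 of the 4 values shown sit.

Still open, on these data alone, is whether the carbonyl or the place of the methyl group on the ring accounts for the step, and a (3-methylphenyl)carbonyl group on that nitrogen would separate the two. An acetyl group or a longer alkyl chain in place of (2-methylphenyl)carbonyl would test whether the aromatic ring is needed at all.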